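A few compounds are considered here, and "the series" means these few. Any claim that something is new, unique, unknown or untested is made for them only; others in the source may bear on it.

Four compounds share a common core, and the question is how a single change on one of them might affect the reading in a functional assay on J774 cells (Mus musculus) for cytotoxicity, with a stated time of 48 h; a lower number here means a stronger inhibitor, a higher number a weaker inhibitor. Compound 1 `CC(C)C[C@H](NC(=O)OC(C)(C)C)C(=O)N1CCC[C@H](C(=O)N2[C@H](C(=O)O)[C@H]2C(=O)O)C1` has no value in this assay: "not determined" (no result reported). The same holds for compound 3 `CC(C)(C)OC(=O)NCC(=O)N1CCC[C@@H](C(=O)N2[C@H](C(=O)O)[C@H]2C(=O)O)C1`, which gives "not determined" (no result reported). Compound 2 `CC(C)(C)OC(=O)NCC(=O)N1CCC[C@@H]1C(=O)N1[C@H](C(=O)OCc2ccccc2)[C@H]1C(=O)OCc1ccccc1` is the only one of the three with any entry, and that entry is a limit of the assay rather than a number: in this assay compound 2 gives > 100000 nM. Where compound 2 stands is therefore set by the limit of > 100000 nM in this assay, at which 1 of the 3 values shown sits, and nothing among the measured compounds places it more precisely than that.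

Compound 4 `CC(C)C[C@H](NC(=O)OC(C)(C)C)C(=O)N1CCC[C@@H]1C(=O)N1[C@H](C(=O)OCc2ccccc2)[C@H]1C(=O)OCc1ccccc1` has not been measured. It differs from compound 2 by isobutyl in place of hydrogen on a saturated chain carbon bound to an amide-type nitrogen and a carbonyl carbon. Among the compounds with values here, no step between two measured compounds is available to show what such a change does in this assay, so the expectation rests on the single limit of compound 2 alone.

The step from compound 2 to compound 4 is expected to be a number no higher from compound 2 to compound 4 (the limit leaves the size open), that is, no movement beyond the scatter, with the result most likely to be reported again as a limit. Compound 4 is expected to give 100000 nM, with a range from 30000 nM to 300000 nM.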

Compound 4, half-maximal inhibitory concentration: > 100000 nM
Compound 4: no number, only a limit (the forecaster's own chance of this, stated with the estimate: 75%); the middle value sits exactly at the limit.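

In this assay, compound 2 and compound 4 each give a limit rather than a number, so no step between them can be read: the limit of > 100000 nM in this assay, at which 2 of the 4 values shown sit.

The compounds shown leave open whether isobutyl in place of hydrogen changes the reading at all, and how far past the limit either compound actually lies.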